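Nitro for fluoro on the core of compound 1

The source may report more compounds than this note shows. Statements on the series, on what has been measured and on what is new or still open speak of the compounds shown alone.

Compound 1 `CCn1c(/C=C2/C(=O)Nc3ccc(F)cc32)nc2ccccc21` is inactive as far as the read-out reaches: in a functional assay on BT-549 cells (Homo sapiens) for cytotoxicity, read by MTT assay, with a stated time of 48 h (on this read-out lower numbers stand for stronger inhibition and higher numbers for weaker inhibition), compound 1 returns only the assay limit > 50000 nM. Compound 2 `Cn1c(/C=C2/C(=O)Nc3ccc(F)cc32)nc2ccccc21`, with hydrogen in place of methyl on a saturated chain carbon bound to an aromatic nitrogen, gives 26900 nM in this assay; the step of an at least 1.8-fold lower number from compound 1 to compound 2 (0.26 log units; that floor lies within the scatter) is the only measured one and is tied to the limit of > 50000 nM in this assay, at which 1 of the 2 values shown sits, so it says little about the substituent on the ring.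

Compound 3 `CCn1c(/C=C2/C(=O)Nc3ccc([N+](=O)[O-])cc32)nc2ccccc21` carries nitro in place of fluoro on an aromatic carbon, (nitro in place of fluoro on an aromatic carbon). For the measured compounds named here, no measured step touches the six-membered aromatic ring of carbon only, so nothing in hand supports a shift of any size in either direction. The step of a number no higher from compound 1 to compound 3 (the limit leaves the size open) is therefore expected to stay near zero, with compound 3 likely sitting at the limit again. Compound 3 is expected at about 50000 nM in this assay, within the range 15000 nM to 160000 nM.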

Compound 3, half-maximal inhibitory concentration: > 50000 nM
Compound 3 gave a limit, no number; the forecaster's own chance of this, stated with the estimate: 60%; the middle value sits exactly at the limit.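

Compound 1 and compound 3 both return only a limit in this assay, so the step between them cannot be read: the limit of > 50000 nM in this assay, at which 2 of the 3 values shown sit.

What nitro in place of fluoro on an aromatic carbon does to the value, in size or direction, stays open with the compounds shown.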